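Swapping a dichlorophenyl for pyridine on a tricyclic agonist

The source may hold more compounds than are shown below. What is called first, only, known or untested is meant among the compounds shown, and "the series" means these compounds.

Measured compounds:
compound 1 `CCCCNc1nc(N)nc2c1CN(Cc1ccccc1Cl)CC2` gives 0.05 uM
compound 2 `CCCCNc1nc(N)nc2c1CN(Cc1c(Cl)cccc1Cl)CC2` gives 0.14 uM

Both compounds were tested in an assay on HEK293 cells for agonist activity at Toll-like receptor 8 (Homo sapiens), read by a luciferase reporter, with a stated time of 6 h; on this read-out lower numbers stand for an effect already at smaller amounts and higher numbers for an effect only at larger amounts of compound. Among the compounds with values here, of the two numbers, compound 2 carries the higher one; its only neighbour is compound 1, and the change of a 2.8-fold higher number from compound 1 to compound 2 (0.45 log units; beyond the scatter) was a chloro in place of hydrogen on an aromatic carbon.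

Compound 3 `CCCCNc1nc(N)nc2c1CN(Cc1ccncc1)CC2` has not yet been measured. It differs from compound 2 by pyridin-4-yl in place of 2,6-dichlorophenyl on a saturated chain carbon bound to an amine nitrogen in a ring. Within the data shown here, no measured step exchanges the whole aromatic group on this saturated chain carbon, so the only guide is that the one change already seen on this ring, from compound 1 to compound 2, moved the number modestly. For compound 3 a step of a 2.1-fold higher number from compound 2 to compound 3 (0.33 log units; beyond the scatter) is therefore expected, towards a larger amount needed, with a wide range. The estimate for compound 3 is 0.3 uM between 0.05 uM and 2 uM.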

Compound 3, minimum effective concentration: 0.29 uM
Compound 3: the middle estimate sits 1.0-fold (0.01 log units) above what was measured; low and high end bracket the measured number.
By their numbers in this assay, from the lowest: compound 1; then compound 2; then compound 3.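

In this assay the whole aromatic group on the saturated chain carbon bound to an amine nitrogen in a ring can be exchanged, and the compound keeps a measurable effect, with a 2.1-fold higher number from compound 2 to compound 3 (0.32 log units; beyond the scatter) and, measured against the group with a single chlorine, a 5.8-fold higher number from compound 1 to compound 3 (0.76 log units; beyond the scatter) over the same place. Of the three compounds, compound 1 with its 2-chlorophenyl still needs the smallest amount, so pyridin-4-yl, with its ring nitrogen and no chlorine, gives no gain here. No measurement is at hand that would explain this change.

Compound 3 differs from the others both in gaining a ring nitrogen and in losing chlorine, and a plain phenyl group at this place would separate those two changes. Pyridin-3-yl would show whether the site of the nitrogen within the ring matters.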